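From cyanomethyl to 3-cyanopropyl: a flat series

A few compounds are considered here, and "the series" means these few. Any claim that something is new, unique, unknown or untested is made for them only; others in the source may bear on it.

Values in a functional assay on A549 cells (Homo sapiens) for cytotoxicity, read by colorimetric assay and MTT assay; a lower number here means a stronger inhibitor, a higher number a weaker inhibitor:
- compound 1 `CCOC(=O)Cn1c(=O)c(-c2ccc(OC)cc2)cc2c(OC)cc(OC)cc21` gives 10000 nM
- compound 2 `CCN(CC)C(=O)Cn1c(=O)c(-c2ccc(OC)cc2)cc2c(OC)cc(OC)cc21` gives 10000 nM
- compound 3 `COc1ccc(-c2cc3c(OC)cc(OC)cc3n(CC#N)c2=O)cc1` gives 10000 nM

Compound 3 stands level with compound 1 and compound 2, so the values reported do not separate the three. Compound 4 `COc1ccc(-c2cc3c(OC)cc(OC)cc3n(CCCC#N)c2=O)cc1` keeps the shared core and differs from compound 3 only in its nitrile side chain: 2-cyanoethyl in place of cyano on a saturated chain carbon bound to an aromatic nitrogen. Here 2-cyanoethyl comes in place of cyano on a saturated chain carbon bound to an aromatic nitrogen.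

Two measured steps change the group at this place, namely no change at the digits printed from compound 1 to compound 3 (within the scatter) and no change at the digits printed from compound 2 to compound 3 (within the scatter). A third step, no change at the digits printed from compound 1 to compound 2 (within the scatter), changes the group on the carbonyl carbon. As far as these compounds go, none of the three lengthens a nitrile chain, so the change itself remains untested. With all three steps flat, no shift beyond the scatter is expected in this assay, and the estimate is no change at the digits printed from compound 3 to compound 4 (within the scatter) in this assay. Compound 4 is expected near 10000 nM with an estimated range from 4500 nM to 20000 nM in this assay.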

Compound 4, half-maximal inhibitory concentration: 10000 nM
Compound 4: middle estimate and measured number agree at the digits printed; low and high end bracket the measured number.
By their numbers in this assay, from the lowest: compounds 1, 2, 3 and 4 (each within the scatter of the next).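

In this assay, the step that lengthens the nitrile side chain, from cyanomethyl to 3-cyanopropyl on the shared core, reads no change at the digits printed from compound 3 to compound 4 (within the scatter), so this extension on a saturated chain carbon bound to an aromatic nitrogen leaves the reading flat. The same group set against the two carbonyl side chains reads no change at the digits printed from compound 2 to compound 4 (within the scatter) for diethylcarbamoyl and no change at the digits printed from compound 1 to compound 4 (within the scatter) for ethoxycarbonyl, so neither chain length nor the type of side chain separates these four compounds. No evidence is available to account for this flat reading.

The compounds shown leave open whether any group at this place can move the value in this assay, such as a carboxylic acid, an amine or a nitrile chain longer than 3-cyanopropyl.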